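The source may report more compounds than this note shows. Statements on the series, on what has been measured and on what is new or still open speak of the compounds shown alone.

In a functional assay on a cell-free system (plasma, Oryctolagus cuniculus) for inhibition, with stated times of 5 min, 1 min and 6 min (a higher number here means a weaker inhibitor, a lower number a stronger inhibitor), compound 1 `CCOC(=O)c1c(C)nc(-c2cccc(C#N)c2)n1OC`, with methoxy on an aromatic nitrogen, gives 9130 nM. Compound 2 `CCOC(=O)c1c(C)nc(-c2cccc(C#N)c2)n1C(C)C`, with isopropyl there, gives 9260 nM, and the change is a 1.0-fold higher number from compound 1 to compound 2 (0.01 log units; within the scatter). Compound 3 `CCOC(=O)c1c(C)nc(-c2cccc(C#N)c2)n1OCC(N)=O` reads > 30000 nM, which is a limit of the assay and not a number. Compound 4 `CCOC(=O)c1c(C)nc(-c2cccc(C#N)c2)n1OCc1ccccc1` has phenyl in place of carbamoyl on a saturated chain carbon bound to an oxygen on an aromatic ring. Among the compounds with values here, two measured steps bear on this. Carbamoyl in place of hydrogen gave an at least 3.2-fold higher number from compound 1 to compound 3 (0.51 log units; beyond the scatter), and carbamoylmethoxy in place of isopropyl gave an at least 3.2-fold higher number from compound 2 to compound 3 (0.51 log units; beyond the scatter). With the carbamoyl gone, the expected change is an at least 3.0-fold lower number from compound 3 to compound 4 (0.47 log units; beyond the scatter), towards a lower number. Within the data shown here, no measured compound carries phenyl, so this expectation is loose. For compound 4 the estimated value is 10000 nM, within a range of 3000 nM to 28000 nM.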

Compound 4, half-maximal inhibitory concentration: 5930 nM
The estimate for compound 4 lay 1.7-fold (0.23 log units) above the measured number; low and high end bracket the measured number.
By their numbers in this assay, from the lowest: compounds 4, 1 and 2 (each within the scatter of the next). At a limit, above all of these: compound 3.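

Compound 3 reads at a limit and not a number: the limit of > 30000 nM in this assay, at which 1 of the 4 values shown sits.

In this assay, phenyl in place of carbamoyl on this chain carbon gives an at least 5.0-fold lower number from compound 3 to compound 4 (0.70 log units; beyond the scatter) and so brings back measurable inhibition. The benzyloxy group matches the smaller groups on the aromatic nitrogen (a 1.5-fold lower number from compound 1 to compound 4 (0.19 log units; within the scatter); a 1.6-fold lower number from compound 2 to compound 4 (0.19 log units; within the scatter)), so this position accepts an added aromatic ring without a change beyond the scatter. The compounds shown leave open whether an amine or a carboxylic acid on this chain carbon would read like carbamoyl or like phenyl, and whether a longer chain carrying the phenyl would keep the inhibition.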